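This account rests on a few compounds, and the source may have more. Where it says the series, first, only, none or still open, it means among the compounds named here.

compound 1 `CCOc1cc2[nH]c(Cc3nn(CC(=O)O)c(=O)c4ccccc34)nc2cc1Cl` gives 0.3 h
compound 2 `O=C(O)Cn1nc(Cn2cc3cc(OCC4CC4)c(Cl)cc3n2)c2ccccc2c1=O` gives 1.4 h
compound 3 `CC(C(=O)O)c1nn(Cc2cn3cc(OCC4CC4)c(C(F)(F)F)cc3n2)c2ccccc2c1=O` gives 1.9 h

In an ADME assay on the whole organism (Mus musculus, strain CD1) for metabolic stability, read by LC-MS, with a stated time of 24 h, at a dose of 1 mg/kg by the intravenous route (a higher number here means that the compound lasts longer, a lower number that the compound disappears faster), compound 1 gives 0.3 h as the lowest of the three numbers, and compound 2 and compound 3 each stand higher by more than the usual scatter. Compound 4 `O=C(O)Cn1nc(Cc2nc3cc(Cl)c(OCC4CC4)cc3[nH]2)c2ccccc2c1=O` differs from compound 1 in one place. The change is cyclopropyl in place of methyl on a saturated chain carbon bound to an oxygen on an aromatic ring and puts cyclopropyl in place of methyl on a saturated chain carbon bound to an oxygen on an aromatic ring, which turns ethoxy into cyclopropylmethoxy. Going by the values given here, no pair of measured compounds isolates this change, so its size cannot be read directly. Compound 2 at 1.4 h and compound 3 at 1.9 h both carry cyclopropylmethoxy, but they also differ from compound 1 elsewhere, so they offer only a loose hint. In this assay a modest rise is expected, estimated as a 2.7-fold higher number from compound 1 to compound 4 (0.43 log units; beyond the scatter) and only slightly beyond the scatter. For compound 4 the estimate is 0.8 h within a range of 0.3 h to 2 h for the half-life.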

Compound 4, half-life: 0.6 h
Estimate against measurement, compound 4: 1.3-fold (0.12 log units) above, within the range that was stated.
By their numbers in this assay, from the lowest: compounds 1 and 4 (each within the scatter of the next); then compounds 2 and 3 (each within the scatter of the next).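

In this assay, the change of ethoxy to cyclopropylmethoxy can now be read directly on one core, as a 2.0-fold higher number from compound 1 to compound 4 (0.30 log units; within the scatter). This step lies within the usual scatter, so on this core the two groups cannot be told apart by half-life, and the cyclopropyl in place of methyl on this saturated chain carbon has no resolved effect in this single pair. No supporting measurement here offers an explanation for this result.

From the compounds shown here alone, it remains open whether a different group at this place, such as a longer chain like butyl or a phenyl ring, would move the half-life beyond the scatter. Also open, going by these compounds, is whether the ethoxy to cyclopropylmethoxy change would read the same on the core of compound 2 or compound 3.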